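Chloro for dimethylamino on a weak growth inhibitor

The source may report more compounds than this note shows. Statements on the series, on what has been measured and on what is new or still open speak of the compounds shown alone.

Going by the values given here, in a functional assay on DU-145 cells (Homo sapiens) for inhibition, read by trypan blue exclusion, with a stated time of 96 h (on this read-out higher numbers stand for weaker inhibition of growth and lower numbers for stronger inhibition of growth), compound 1 `Cc1ccc(CS(=O)(=O)/C(=C/c2ccc(N(C)C)cc2)C(=O)c2ccc(Cl)cc2)cc1` gives 50000 nM as the only exact number so far. Compound 2 `Cc1ccc(S(=O)(=O)/C(=C/c2ccc(N(C)C)cc2)C(=O)c2ccc(Cl)cc2)cc1` shows > 100000 nM which is a limit of the assay and not a number. Among the compounds with values here, the one measured step is an at least 2.0-fold higher number from compound 1 to compound 2 (0.30 log units; that floor lies within the scatter) and it sits on the sulfonyl sulfur, so it sets no size for the next change. Compound 3 `Cc1ccc(CS(=O)(=O)/C(=C/c2ccc(Cl)cc2)C(=O)c2ccc(Cl)cc2)cc1` carries chloro in place of dimethylamino on an aromatic carbon with the rest unchanged. Within the data shown here, no step at that place has been measured, so the expectation in this assay stays close to compound 1 at 50000 nM for now. The estimated step is a 1.7-fold lower number from compound 1 to compound 3 (0.22 log units; within the scatter) at its middle. Compound 3 is expected at 30000 nM with an estimated range from 5000 nM to 100000 nM around that middle.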

Compound 3, concentration for 50% growth inhibition: 25000 nM
Estimate against measurement, compound 3: 1.2-fold (0.08 log units) above, and the stated range covers the measured number.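

Chloro in place of dimethylamino on this aromatic carbon gives a 2.0-fold lower number from compound 1 to compound 3 (0.30 log units; within the scatter), the first step read at this place. Compound 1 and compound 3 therefore cannot be told apart, so in these two compounds the dimethylamino group is not needed for the weak growth inhibition seen. The data shown give no cause for this step. As far as these compounds go, whether a methoxy group, a carboxylic acid or a longer amine chain at this place would give a step beyond the scatter stays open.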